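The source may hold more compounds than are shown below. What is called first, only, known or untested is meant among the compounds shown, and "the series" means these compounds.

In an ADME assay on KB cells (Homo sapiens) for cytotoxicity, read by MTT assay, with a stated time of 72 h (a lower number here means a stronger inhibitor, a higher number a weaker inhibitor), compound 1 `COc1ccc(OC)c(C2=C(c3cc(OC)c(OC)c(OC)c3)C(=O)CC2O[SiH2]C(C)(C)C)c1` gives 10 ug/mL and compound 2 `COc1ccc(C2=C(c3cc(OC)c(OC)c(OC)c3)C(=O)CC2OC(C)=O)cc1NC=O` gives 8 ug/mL, two values within the usual scatter of each other. Compound 3 `COc1ccc(OC)c(C2=C(c3cc(OC)c(OC)c(OC)c3)C(=O)CC2O)c1` is reported only as a limit, > 100 ug/mL.

The change now followed leads to compound 4 `COCOc1cc(C2=C(c3cc(OC)c(OC)c(OC)c3)C(=O)CC2O[SiH2]C(C)(C)C)ccc1OC`, with 4-methoxy-3-(methoxymethoxy)phenyl in place of 2,5-dimethoxyphenyl on a double-bonded ring carbon. Among the measured compounds shown here, the one measured step, an at least 10-fold higher number from compound 1 to compound 3 (1.00 log units; beyond the scatter), lies beyond the scatter, but it replaces the group on oxygen with a hydrogen atom. Compound 4 keeps that group, so this step says little about the new change. For the measured compounds named here, no measured step alters the aromatic group that is exchanged here, and the size of any effect remains open. No shift beyond the scatter is therefore expected in this assay, and the estimated change is a 1.3-fold lower number from compound 1 to compound 4 (0.10 log units; within the scatter). The estimate for compound 4 is 8 ug/mL, with an expected range of 2 ug/mL to 35 ug/mL.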

Compound 4, half-maximal inhibitory concentration: 33 ug/mL
For compound 4 the middle estimate is 4.1-fold (0.62 log units) below the measured one; the measured number falls inside the stated range.
By their numbers in this assay, from the lowest: compounds 2 and 1 (each within the scatter of the next); then compound 4. At a limit, above all of these: compound 3.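

With the group on oxygen kept, the exchange of 2,5-dimethoxyphenyl for 4-methoxy-3-(methoxymethoxy)phenyl gives a 3.3-fold higher number from compound 1 to compound 4 (0.52 log units; beyond the scatter) in this assay, a modest step that lies beyond the scatter. Among the compounds shown here, the only earlier step changed the group on oxygen on a saturated carbon, so this is the first sign that the aromatic group on the double-bonded ring carbon also moves the number. No measurement shown explains this shift.

The exchange alters the methoxy and methoxymethoxy groups together, so the compounds shown do not separate their contributions. As far as these compounds go, it also remains open how a hydroxyl group or an amine in place of the methoxymethoxy group would read in this assay, or whether the step would hold with another group on oxygen.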